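Butylamide in place of the acid on a fluorouracil nucleoside

The source may report more compounds than this note shows. Statements on the series, on what has been measured and on what is new or still open speak of the compounds shown alone.

Compound 1, `CCOC(=O)CCC(=O)NC[C@H]1O[C@@H](n2cc(F)c(=O)[nH]c2=O)C[C@@H]1O`, in a functional assay on T-24 cells (Homo sapiens) for cytotoxicity (on this read-out lower numbers stand for stronger inhibition and higher numbers for weaker inhibition), reaches only a limit of the assay, > 280000 nM.
Compound 2, `O=C(O)/C=C/C(=O)NC[C@H]1O[C@@H](n2cc(F)c(=O)[nH]c2=O)C[C@@H]1O`, in this assay gives 231000 nM.

Among the measured compounds shown here, compound 2 holds the only number in this assay; the other value shown is a limit, so its standing among the measured compounds cannot be ranked. The step of an at least 1.2-fold lower number from compound 1 to compound 2 (0.08 log units; that floor lies within the scatter) is bounded by the limit of > 280000 nM in this assay, at which 1 of the 2 values shown sits, and gives no clear direction.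

Compound 3, `CCCCNC(=O)/C=C/C(=O)NC[C@H]1O[C@@H](n2cc(F)c(=O)[nH]c2=O)C[C@@H]1O`, differs from compound 2 by butylamino in place of hydroxy on a carbonyl carbon. For the measured compounds named here, no measured step touches this change: the one step recorded swaps the whole 2-(ethoxycarbonyl)ethyl arm for the 2-carboxyethenyl arm and its floor sits within the scatter. The expectation for compound 3 therefore rests on the weak inhibition seen for compound 2 at 231000 nM and on the absence of any step beyond the scatter, so compound 3 is expected to sit close to compound 2 in this assay, with a 1.2-fold lower number from compound 2 to compound 3 (0.06 log units; within the scatter) as the expected step. Compound 3 is estimated at 200000 nM, between 60000 nM and 600000 nM, with a fair chance that only a limit is reported.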

Compound 3, half-maximal inhibitory concentration: > 300000 nM
Compound 3 gave a limit, no number (the forecaster's own chance of this, stated with the estimate: 35%); at least 1.5-fold (0.17 log units) between middle value and limit.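

Among the compounds shown here, on the carbonyl carbon of the 2-carboxyethenyl arm, the change from hydroxy to butylamino is the first change made at this one place, and in this assay it gives an at least 1.2-fold higher number from compound 2 to compound 3 (0.11 log units; that floor lies within the scatter), so it reveals no gain in inhibition and no separation that can be relied on. Compound 3 reaches only a limit of the assay, not a number: the limit of > 300000 nM in this assay, at which 1 of the 3 values shown sits. For the compounds shown here, compound 1 and compound 3 both stand at limits, so the step between them cannot be read, and compound 2 remains the only compound of the three with a number, which leaves the butylamide showing nothing stronger than the free acid.

Going by these compounds, how far compound 3 lies past its limit stays open, and with it the true size of the change from hydroxy to butylamino. Also open, on these data alone, is what a primary amide, a longer chain ending in a carboxylic acid, or a butyl chain carrying a terminal amine would give on this carbonyl carbon in this assay.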